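The source may report more compounds than this note shows. Statements on the series, on what has been measured and on what is new or still open speak of the compounds shown alone.

Compound 1 `Cc1c(C)c2ccc(OCC3CCN(Cc4ccc(CO)cc4)CC3)cc2oc1=O`: 29 nM in an assay for inhibition of Amine oxidase [flavin-containing] B (Homo sapiens), read by fluorescence, using microsomes, with a stated time of 30 min; a higher number here means a weaker inhibitor, a lower number a stronger inhibitor.
Compound 2 `Cc1cc2ccc(OCC3CCN(Cc4ccc(CO)cc4)CC3)cc2oc1=O`: 3100 nM in this assay.
Compound 3 `Cc1c(C)c2ccc(OCC3CCN(Cc4ccc(CCO)cc4)CC3)cc2oc1=O`: 120 nM in this assay.

Compound 3 sits second highest of the three numbers: the step of a 4.1-fold higher number from compound 1 to compound 3 (0.62 log units; beyond the scatter) separates it from compound 1, while compound 2 lies well above it on the values alone. Compound 4 `Cc1c(C)c2ccc(OCC3CCN(CCCCO)CC3)cc2oc1=O` differs from compound 3 by 3-hydroxypropyl in place of 4-(2-hydroxyethyl)phenyl on a saturated chain carbon bound to an amine nitrogen in a ring. For the measured compounds named here, no measured step touches this position; a 110-fold higher number from compound 1 to compound 2 (2.03 log units; beyond the scatter) concerns the core and a 4.1-fold higher number from compound 1 to compound 3 (0.62 log units; beyond the scatter) only the chain on the departing ring, so neither gives a direct read. Given the size of the group removed, a step toward a higher number in this assay is expected, but with wide uncertainty: the estimated step is a 5.0-fold higher number from compound 3 to compound 4 (0.70 log units; beyond the scatter). Compound 4 is expected at 600 nM, between 150 nM and 3000 nM.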

Compound 4, half-maximal inhibitory concentration: 3600 nM
Compound 4: middle estimate off by 6.0-fold (0.78 log units), on the low side; measured number outside the range, above it.
By their numbers in this assay, from the lowest: compound 1; then compound 3; then compounds 2 and 4 (each within the scatter of the next).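

Swapping the ring-bearing group for 3-hydroxypropyl on the saturated chain carbon bound to the ring amine nitrogen gives a 30-fold higher number from compound 3 to compound 4 (1.48 log units; beyond the scatter) in this assay, with hydrogen-bond donor and acceptor counts unchanged. Set against the shorter-armed parent, the change gives a 120-fold higher number from compound 1 to compound 4 (2.09 log units; beyond the scatter) and lands in the same way, so a terminal hydroxy on a chain does not by itself keep the number low in this pair of steps. Nothing measured here accounts for the size of these steps.

Open: whether a longer chain ending in hydroxy, a plain benzyl group, or an amine in place of the hydroxy would hold the number down.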